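Swapping the halogenated phenyl on a diketopiperazine-type core

The compounds below may be only part of what the source reports. "The series", "measured", "known", "first", "only" and "open" are said of these compounds alone.

Measured compounds:
compound 1, `C=CCn1c(=O)/c(=C\c2cccc(F)c2)[nH]c(=O)/c1=C\c1ccccc1OC`, 25600 nM
compound 2, `C=CCn1c(=O)/c(=C\c2ccc(Cl)c(Cl)c2)[nH]c(=O)/c1=C\c1ccccc1OC`, "not active" (no number reported)

In a functional assay on NCI-H1975 cells (Homo sapiens) for cytotoxicity, read by CCK-8 assay, with a stated time of 72 h (on this read-out higher numbers stand for weaker inhibition and lower numbers for stronger inhibition), compound 1 gives 25600 nM. In this assay compound 2 gives "not active" (no number reported), so no single number stands for it and its position among the measured compounds cannot be placed on a scale; it is known only that no inhibition was quantified. Compound 3, `C=CCn1c(=O)/c(=C\c2cccc(Br)c2)[nH]c(=O)/c1=C\c1ccccc1OC`, has not yet been measured. It differs from compound 2 in one place: 3-bromophenyl in place of 3,4-dichlorophenyl on a double-bonded chain carbon bound to an aromatic carbon. Going by the values given here, no step between measured compounds connects these two. Among the compounds with values here, the only number available, that of compound 1 with its 3-fluorophenyl group, is very weak, and compound 2 gave none, so any change here is judged against a background of little activity. Compound 3 is therefore expected to fall in the weak range seen for compound 1, with a real chance that this assay again reports no number. The estimate for compound 3 in this assay is 30000 nM, with a range from 8000 nM to 100000 nM.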

Compound 3, half-maximal inhibitory concentration: "not active" (no number reported)
Compound 3 has no reported number here; there is nothing to compare the estimate with.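

No new step can be read, since in this assay compound 2 gives "not active" (no number reported) and compound 3 gives "not active" (no number reported) so neither has a number to compare. The compounds shown leave open whether 3-bromophenyl and 3,4-dichlorophenyl differ at all in cytotoxicity. No supporting measurement bears on this result.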